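The compounds below may be only part of what the source reports. "The series", "measured", "known", "first", "only" and "open" are said of these compounds alone.

Measured so far:
compound 1, `O=S(=O)(NCCNCc1cccc2ccccc12)c1cc(C(F)(F)F)cc(C(F)(F)F)c1`, gives 16000 nM in a functional assay on HT-29 cells (Homo sapiens) for inhibition, read by MTT assay, with a stated time of 72 h; on this read-out higher numbers stand for weaker inhibition of growth and lower numbers for stronger inhibition of growth
compound 2, `O=S(=O)(NCCCNCc1ccccc1Cl)c1cc(C(F)(F)F)cc(C(F)(F)F)c1`, gives 20000 nM in this assay

Compound 2 has the higher of the two numbers, but its gap to compound 1 lies within the usual scatter, so the two read as alike. Compound 3, `CC(C)(C)c1ccc(CNCCCNS(=O)(=O)c2cc(C(F)(F)F)cc(C(F)(F)F)c2)cc1`, differs from compound 2 by 4-(tert-butyl)phenyl in place of 2-chlorophenyl on a saturated chain carbon bound to an amine nitrogen. Among the compounds with values here, no measured pair shows what a change of this kind does here, so there is no basis for expecting a step beyond the scatter in either direction. Compound 3 is therefore estimated at 15000 nM, within a range from 5000 nM to 45000 nM. The expected step is a 1.3-fold lower number from compound 2 to compound 3 (0.12 log units; within the scatter).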

Compound 3, concentration for 50% growth inhibition: 2000 nM
Compound 3: the middle estimate sits 7.5-fold (0.88 log units) above what was measured; the measured number lies below the stated range.
By their numbers in this assay, from the lowest: compound 3; then compounds 1 and 2 (each within the scatter of the next).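

In this assay, putting 4-(tert-butyl)phenyl in place of 2-chlorophenyl on a saturated chain carbon bound to an amine nitrogen gives a 10-fold lower number from compound 2 to compound 3 (1.00 log units; beyond the scatter). The group at this position can therefore shift growth inhibition beyond the scatter, which compounds 1 and 2, alike in their numbers, could not show. Nothing available here explains this shift.

The swap removes the chlorine and adds the tert-butyl group together, so the contribution of each remains unresolved. On these data alone, it also remains open how a plain phenyl or a cyclohexyl group would behave at this position.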